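The source may hold more compounds than are shown below. What is called first, only, known or untested is meant among the compounds shown, and "the series" means these compounds.

Compound 1 `COC1(c2csc(Sc3ccc4c(c3)CC/C4=N\OCC#N)c2)CCOCC1` is the stronger of the two measured compounds: in a functional assay (blood) for inhibition, with Homo sapiens as the target (a lower number here means a stronger inhibitor, a higher number a weaker inhibitor), compound 1 gives 40 nM. Compound 2 `COC(=O)c1cc(CO/N=C(\C)c2ccc(Sc3cc(F)cc(C4CCOCC4)c3)cc2)on1` shares the diaryl sulfide arrangement but carries a different chain on its oxygen; in this assay compound 2 gives 100 nM, the higher of the two numbers, and the gap between compound 2 and compound 1 lies beyond the usual scatter of repeated measurements, so compound 2 stands as the weaker inhibitor of the pair.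

Compound 3 `C/C(=N\OC(=O)C(C)(C)C)c1ccc(Sc2cc(F)cc(C3CCOCC3)c2)cc1` is not yet measured. It differs from compound 2 in one place: (tert-butyl)carbonyl in place of (3-(methoxycarbonyl)-1,2-oxazol-5-yl)methyl on an oxygen. No change of this kind has been measured here, so the direction of the step from compound 2 to compound 3 cannot be read from any shown pair.

The expectation is a small loss, with the step from compound 2 to compound 3 estimated at a 1.8-fold higher number from compound 2 to compound 3 (0.26 log units; within the scatter), close to the edge of the scatter. Compound 3 is therefore expected to give about 180 nM in this assay, with a plausible range from 60 nM to 600 nM.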

Compound 3, half-maximal inhibitory concentration: 40 nM
Compound 3: the middle estimate sits 4.5-fold (0.65 log units) above what was measured; the whole stated range lies above it.
By their numbers in this assay, from the lowest: compounds 1 and 3 (each within the scatter of the next); then compound 2.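

The step shows that the (3-(methoxycarbonyl)-1,2-oxazol-5-yl)methyl group is not required on an oxygen whose other neighbours are a double-bonded nitrogen. In this assay, replacing it with (tert-butyl)carbonyl gives a 2.5-fold lower number from compound 2 to compound 3 (0.40 log units; beyond the scatter), a modest gain that lies beyond the scatter. The entering group has no ring and fewer heavy atoms and hydrogen-bond acceptors than the group it replaces, so at this position, on this core, the smaller group without a ring gives the stronger inhibitor; nothing available accounts for why the step runs in this direction.

For the compounds shown here, the single step replaces the whole group at once, so it cannot tell whether the gain goes with the carbonyl on the oxygen or with the tert-butyl, a question that an acetyl group or a neopentyl chain on the same oxygen would help to separate. It also leaves open how a carboxylic acid in place of the methoxycarbonyl would read, and whether (tert-butyl)carbonyl would give a similar step on the core of compound 1.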